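This account rests on a few compounds, and the source may have more. Where it says the series, first, only, none or still open, it means among the compounds named here.

Measured so far in a functional assay on NCI-H460 cells (Homo sapiens) for cytotoxicity, read by MTT assay, with a stated time of 72 h; on this read-out higher numbers stand for weaker inhibition and lower numbers for stronger inhibition:
compound 1 `COc1cc2c(Oc3ccc(NC(=O)c4nnn(-c5ccc(C)cc5)c4C(F)(F)F)cc3F)ccnc2cc1OCCCN1CCC(C)CC1`: 1250 nM
compound 2 `COc1cc2c(Oc3ccc(NC(=O)c4nnn(-c5ccc(F)c(F)c5)c4C(F)(F)F)cc3F)ccnc2cc1OCCCN1CCC(C)CC1`: 230 nM

Two compounds on the shared core, differing only in the aryl group on the aromatic nitrogen of the five-membered ring. Going by the values given here, the single step between them, a 5.4-fold lower number from compound 1 to compound 2 (0.74 log units; beyond the scatter), is modest but beyond the scatter. Among the compounds with values here, compound 2 therefore stands lowest of the two numbers in this assay, with compound 1 as its only and nearest neighbour.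

Compound 3 `COc1cc2c(Oc3ccc(NC(=O)c4nnn(-c5cccc(Br)c5)c4C(F)(F)F)cc3F)ccnc2cc1OCCCN1CCC(C)CC1` differs from compound 2 as 3-bromophenyl in place of 3,4-difluorophenyl on an aromatic nitrogen. Within the data shown here, the only step that bears on this position is a 5.4-fold lower number from compound 1 to compound 2 (0.74 log units; beyond the scatter), which exchanged 4-methylphenyl for 3,4-difluorophenyl; it shows that the group on this aromatic nitrogen can shift the number by more than the scatter, but neither 3-bromophenyl nor any compound with a single halogen on that ring has been measured, so the direction for the present change is not fixed by the data. The expected step, a 1.5-fold higher number from compound 2 to compound 3 (0.18 log units; within the scatter), is small and within the scatter, with a broad range to either side. Compound 3 is estimated at 350 nM, range 120 nM to 1200 nM.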

Compound 3, half-maximal inhibitory concentration: 450 nM
Estimate against measurement, compound 3: 1.3-fold (0.11 log units) below; low and high end bracket the measured number.
By their numbers in this assay, from the lowest: compounds 2 and 3 (each within the scatter of the next); then compound 1.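

In this assay the exchange of 3,4-difluorophenyl for 3-bromophenyl on the aromatic nitrogen gives a 2.0-fold higher number from compound 2 to compound 3 (0.29 log units; within the scatter) and so does not separate a ring with one bromine from a ring with two fluorines on this read-out. Against the 4-methylphenyl group, the same 3-bromophenyl group gives a 2.8-fold lower number from compound 1 to compound 3 (0.44 log units; beyond the scatter) and thus joins 3,4-difluorophenyl on the lower side of compound 1 by more than the scatter, a pattern that holds for both halogen-bearing rings here, with neither of the three compounds going against it. No evidence at hand accounts for either step.

From the compounds shown here alone, whether the lower numbers of compound 2 and compound 3 go with the halogens themselves or with the loss of the 4-methyl group stays open, and unsubstituted phenyl on this nitrogen would separate the two readings. Also open, going by these compounds, is how 4-bromophenyl, 3-fluorophenyl, or a phenyl ring carrying an amine or a carboxylic acid would stand in this assay on the same shared core.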